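Changing the amide end of compound 1

This account rests on a few compounds, and the source may have more. Where it says the series, first, only, none or still open, it means among the compounds named here.

In a functional assay on MDA-MB-231 cells (Homo sapiens) for inhibition, read by sulforhodamine B assay, with a stated time of 72 h (a lower number here means a stronger inhibitor of growth, a higher number a weaker inhibitor of growth), compound 1 (`CNC(=O)/C=C/c1ccncc1-c1ccc2ccccc2c1`) gives 8680 nM as its growth-inhibition value. Among the compounds with values here, its only measured neighbour, compound 2 (`CNC(=O)CCc1ccncc1-c1ccc2ccccc2c1`), gives 8980 nM and cannot be told apart from it. Compound 3 (`COC1CN(C(=O)/C=C/c2ccncc2-c2ccc3ccccc3c2)C1`) keeps the core of compound 1 but carries 3-methoxyazetidin-1-yl in place of methylamino on a carbonyl carbon. Within the data shown here, the one measured step (a 1.0-fold higher number from compound 1 to compound 2 (0.01 log units; within the scatter)) alters the chain holding that carbonyl, not the group on it, so it bears only loosely on this change. Among the measured compounds shown here, no measured compound varies the group swapped here. With so little to go on, no step beyond the scatter is expected in this assay and no direction can be given, though the uncertainty is wide. The expected change is small (a 1.1-fold lower number from compound 1 to compound 3 (0.04 log units; within the scatter)) on this reasoning. For compound 3 the estimated value is 8000 nM with 2500 nM to 25000 nM as the expected range.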

Compound 3, concentration for 50% growth inhibition: > 10000 nM
Compound 3 ended at the assay's limit; the forecaster's own chance of this, stated with the estimate: 10%; middle value at least 1.2-fold (0.09 log units) away from the limit.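

Within the data shown here, this is the first look at the group on the carbonyl carbon, and in this assay compound 3 gives > 10000 nM, which is a limit of the assay and not a number. Putting 3-methoxyazetidin-1-yl in place of methylamino removes the amide hydrogen and adds a four-membered ring, yet it brings no lower number: the step reads an at least 1.1-fold higher number from compound 1 to compound 3 (0.06 log units; that floor lies within the scatter). The change therefore gives no gain in growth inhibition, but any loss cannot be sized: the limit of > 10000 nM in this assay, at which 1 of the 3 values shown sits.

How far compound 3 really lies from compound 1 stays unsettled, as its floor does not separate the two. Also open, from the compounds shown here alone, is whether dimethylamino, which likewise has no amide hydrogen, or a carboxylic acid at this carbonyl carbon would move the number in either direction.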